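Homologation and re-methylation at the aryl ether of compound 2

The source may hold more compounds than are shown below. What is called first, only, known or untested is meant among the compounds shown, and "the series" means these compounds.

Among the compounds with values here, compound 2 `Nc1nc(CCc2ccc(O)cc2)nc2cn(-c3ccccc3)nc12` gives 37% in an assay on CHO cells for displacement of a labelled ligand from adenosine receptor A3 (Homo sapiens), read by scintillation counting, tested at 1 uM (a higher number here means more inhibition at the concentration tested (going by the name of the read-out), a lower number less inhibition), the highest of the two numbers measured so far, with compound 1 `COc1ccc(CCc2nc(N)c3nn(-c4ccccc4)cc3n2)cc1` next at 22%. Within the data shown here, the only measured step is a number 15 percentage points higher from compound 1 to compound 2 (beyond the scatter), hydrogen in place of methyl on an oxygen on an aromatic ring. Compound 3 `COc1ccc(CCCc2nc(N)c3nn(-c4ccccc4)cc3n2)cc1` carries 4-methoxybenzyl in place of 4-hydroxyphenyl on a saturated chain carbon, two bonds along the chain from an aromatic carbon. This change puts the methyl back on the oxygen, as in compound 1, and in addition lengthens the saturated chain. The measured step bears on the first part of the change: reversing it is expected to lower the number by roughly the same amount, because a number 15 percentage points higher from compound 1 to compound 2 (beyond the scatter) was the gain from removing the methyl. Among the measured compounds shown here, no measured step speaks to the longer chain, so the range is widened. A step of a number 17 percentage points lower from compound 2 to compound 3 (beyond the scatter) is therefore expected. Compound 3 is estimated at 20%, in the range 5% to 40%.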

Compound 3, a percentage reported as inhibition, at one concentration (the size of the read-out at that concentration, not a potency): 1%
Beside the measured number, compound 3's estimate is 19 percentage points above it, outside the stated range (below it).
By their numbers in this assay, from the lowest: compound 3; then compound 1; then compound 2.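

With the methoxy group held fixed, the longer saturated chain alone gives a number 21 percentage points lower from compound 1 to compound 3 (beyond the scatter) in this assay and so counts against inhibition at this position, which the earlier pair could not show. Taken together, the chain extension and the restored methyl give a number 36 percentage points lower from compound 2 to compound 3 (beyond the scatter) in this assay and leave the shorter chain with the free hydroxyl highest of the three compounds. No supporting data explain this loss.

Still open, on these data alone, is whether a hydroxyl on the longer chain would recover inhibition, and whether a still longer chain would take the number further down. Also open, as far as these compounds go, is how an amine or a carboxylic acid in place of the oxygen group on the aromatic ring would read on either chain length.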